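The compounds below may be only part of what the source reports. "The series", "measured", "known", "first", "only" and "open" are said of these compounds alone.

The three measured compounds are compound 1 `OCCC(F)CF`, compound 2 `FC(F)CCOc1ccc2[nH]ccc2c1` and compound 3 `OCCC(F)F`. In a physicochemical assay for lipophilicity, read by NMR (on this read-out lower numbers stand for lower lipophilicity and higher numbers for higher lipophilicity), compound 1 gives -0.12, compound 3 gives 0.04, and compound 2 gives 2.6, the highest of the three numbers, the nearest being compound 3 and the furthest compound 1. Compound 4 `CCCOc1ccc2[nH]ccc2c1` differs from compound 2 by methyl in place of difluoromethyl on a saturated chain carbon, two bonds along the chain from an oxygen on an aromatic ring. Within the data shown here, the only measured step that touches a chain fluorine is a number 0.16 log units higher from compound 1 to compound 3 (within the scatter), and it stays within the scatter. For the change to compound 4 a step of about a number 0.30 log units higher from compound 2 to compound 4 (within the scatter) is expected, small and upward if anything. Compound 4 is therefore estimated at 2.9, in a range from 2.5 to 3.3.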

Compound 4, partition coefficient: 2.9
For compound 4 middle estimate and measured number coincide at the digits printed; the range from low to high includes it.
By their numbers in this assay, from the lowest: compounds 1 and 3 (each within the scatter of the next); then compounds 2 and 4 (each within the scatter of the next).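

Taking out both fluorines by putting methyl in place of difluoromethyl gives, in this assay, a number 0.30 log units higher from compound 2 to compound 4 (within the scatter), so this change on a saturated chain carbon, two bonds along the chain from an oxygen on an aromatic ring, stays within the scatter. The earlier step concerned only the short chain alcohols, whereas this one is read on the shared core of compound 2 and compound 4. No measurement shown gives a reason for this result. As far as these compounds go, whether trifluoromethyl, an amine or a longer chain in the same place would also stay within the scatter of compound 2 remains open.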